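Compound 4: dimethylamino in place of methoxy

A few compounds are considered here, and "the series" means these few. Any claim that something is new, unique, unknown or untested is made for them only; others in the source may bear on it.

Three compounds have numbers in an assay for binding affinity to leukotriene B4 receptor 1 (Homo sapiens); a higher number here means a weaker inhibitor, a lower number a stronger inhibitor. Compound 1 `COc1ccc(CCCCCCCCOc2ccc(C[S+]([O-])c3cccc(NS(=O)(=O)c4ccccc4)c3)nc2/C=C/C(=O)O)cc1` gives 147 nM. Compound 2 `COc1ccc(CCCCCCCCOc2ccc(CSc3cccc(OC)c3)nc2/C=C/C(=O)O)cc1` gives 192 nM. Compound 3 `COc1ccc(CCCCCCCCOc2ccc(C[S+]([O-])c3cccc(OC)c3)nc2/C=C/C(=O)O)cc1` gives 232 nM, the highest of the three numbers, yet both gaps stay within the scatter: a 1.6-fold higher number from compound 1 to compound 3 (0.20 log units; within the scatter) and a 1.2-fold higher number from compound 2 to compound 3 (0.08 log units; within the scatter). On these numbers compound 3 cannot be told apart from compound 1 or from compound 2.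

Compound 4 `COc1ccc(CCCCCCCCOc2ccc(C[S+]([O-])c3cccc(N(C)C)c3)nc2/C=C/C(=O)O)cc1` carries dimethylamino in place of methoxy on an aromatic carbon. Among the measured compounds shown here, the closest parallel among the measured steps is the one from compound 1 to compound 3, which also exchanges the group on this same aromatic carbon; there a (phenylsulfonyl)amino gave way to a methoxy and the number moved only within the scatter. The step from compound 2 to compound 3 touches another part of the molecule and was likewise within the scatter. For the measured compounds named here, nothing so far shows an exchange at this aromatic carbon that carries the number beyond the scatter. The expected step is therefore a 1.1-fold lower number from compound 3 to compound 4 (0.02 log units; within the scatter), with no direction beyond the scatter. Compound 4 is expected to give 220 nM, in a range from 110 nM to 450 nM.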

Compound 4, inhibition constant: 245 nM
Estimate against measurement, compound 4: 1.1-fold (0.05 log units) below; low and high end bracket the measured number.
By their numbers in this assay, from the lowest: compounds 1, 2, 3 and 4 (each within the scatter of the next).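

In this assay, replacing 3-methoxyphenyl with 3-(dimethylamino)phenyl gives a 1.1-fold higher number from compound 3 to compound 4 (0.02 log units; within the scatter), so a nitrogen-linked group on this aromatic carbon now joins the oxygen-linked methoxy without separating from it. Dimethylamino also stays unresolved from the much larger (phenylsulfonyl)amino, with a 1.7-fold higher number from compound 1 to compound 4 (0.22 log units; within the scatter), so compounds 1, 3 and 4 show three groups on this carbon that the assay does not distinguish, and no exchange here has yet moved the number beyond the scatter. The change on the saturated chain carbon that links compound 2 to the new compound gives a 1.3-fold higher number from compound 2 to compound 4 (0.11 log units; within the scatter), which is also unresolved, and no measurement is available to explain the flat response at this position.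

The compounds shown leave open whether a carboxylic acid or a primary amine on this aromatic carbon would carry the number beyond the scatter in either direction. They also leave open whether a longer chain in place of the one shared by all four compounds would shift the number more than any exchange on this aromatic carbon has so far.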